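This account rests on a few compounds, and the source may have more. Where it says the series, first, only, none or still open, it means among the compounds named here.

In a functional assay (aorta) with Rattus norvegicus as the target (a higher number here means a weaker inhibitor, a lower number a stronger inhibitor), the measured compounds gave these numbers:
Compound 1 `CCO/C(O)=C1\C(COCCn2cc(N)n(C)c2=O)=NC(C)=C(C(=O)OC)C1c1ccccc1Cl` gives 25.1 nM
Compound 2 `CCO/C(O)=C1\C(COCCn2cc(C(N)=O)nn2)=NC(C)=C(C(=O)OC)C1c1ccccc1Cl` gives 20 nM
Compound 3 `CCO/C(O)=C1\C(COCCN2CC(=O)N=C2N)=NC(C)=C(C(=O)OC)C1c1ccccc1Cl` gives 20 nM

Compound 3 stands level with compound 2, the two together the lowest of the three, and its gap to compound 1 is within the scatter. Compound 4 `CCO/C(O)=C1\C(COCCn2cc(N)nc2O)=NC(C)=C(C(=O)OC)C1c1ccccc1Cl` differs from compound 3 in the same place where all three measured compounds differ from one another: a group of 7 heavy atoms (3 carbon, 3 nitrogen, 1 oxygen; one five-membered aromatic ring with 2 hetero atoms) in place of a group of 7 heavy atoms (3 carbon, 3 nitrogen, 1 oxygen; one five-membered non-aromatic ring with 2 hetero atoms), on a saturated chain carbon, two bonds along the chain from an oxygen on a saturated carbon. The steps there were a 1.3-fold lower number from compound 1 to compound 2 (0.10 log units; within the scatter), a 1.3-fold lower number from compound 1 to compound 3 (0.10 log units; within the scatter) and no change at the digits printed from compound 2 to compound 3 (within the scatter), each within the scatter. Swapping one small ring for another at this position has so far left the number where it was, so no shift beyond the scatter is expected. Compound 4 is estimated at 20 nM, with a range from 10 nM to 40 nM. The expected step in this assay is no change at the digits printed from compound 3 to compound 4 (within the scatter).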

Compound 4, half-maximal inhibitory concentration: 31.6 nM
Estimate against measurement, compound 4: 1.6-fold (0.20 log units) below; the measured number falls inside the stated range.
By their numbers in this assay, from the lowest: compounds 2, 3, 1 and 4 (each within the scatter of the next).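

In this assay steps of a 1.6-fold higher number from compound 3 to compound 4 (0.20 log units; within the scatter) and a 1.6-fold higher number from compound 2 to compound 4 (0.20 log units; within the scatter) and a 1.3-fold higher number from compound 1 to compound 4 (0.10 log units; within the scatter) show that 4-amino-2-hydroxy-1H-imidazol-1-yl also fits at this position without a shift beyond the scatter. Compound 3 and compound 4 hold the same atoms joined differently, so at this position a five-membered aromatic ring and a five-membered non-aromatic ring cannot be told apart here. No measurement on hand bears on this result. It remains open whether a ring is needed here at all, since every compound shown carries one. A plain amine or a carboxylic acid in place of the ring, or a longer chain carrying it, might move the number further.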